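The source may hold more compounds than are shown below. What is called first, only, known or untested is meant among the compounds shown, and "the series" means these compounds.

Measured so far:
Compound 1 `C=CCn1c(=O)n([C@@H]2O[C@H](CO)[C@H]3OC(C)(CCC(=O)NC)O[C@H]32)c2nc(N)nc(O)c21`, giving 9% in a functional assay on the whole organism (B cells) with Mus musculus as the target; a lower number here means a smaller maximal response, a higher number a larger maximal response
Compound 2 `C=CCn1c(=O)n([C@@H](CO)OC(CO)CO)c2nc(N)nc(O)c21`, giving 0% in this assay

Both measured compounds share the same core. Within the data shown here, the value of compound 1 and the value of compound 2 lie within the scatter of each other, so neither can be set apart from the other; compound 1 simply stands at a small maximal response, and no step between two measured compounds is known that would show how a change of a single group moves this read-out.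

Compound 3 `C=CCn1c(=O)n([C@@H]2O[C@H](CO)[C@H]3OC(C)(CCC(=O)OCC)O[C@H]32)c2nc(N)nc(O)c21` is not yet measured. It differs from compound 1 in one place: ethoxy in place of methylamino on a carbonyl carbon. Among the measured compounds shown here, with no measured step to lean on, the expectation rests on compound 1 alone, whose 9% is a small maximal response. The step from compound 1 to compound 3 is expected to be no change at the digits printed from compound 1 to compound 3 (within the scatter), not beyond the scatter in either direction. For compound 3 the estimate is therefore 9%, with a range from 0% to 25%.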

Compound 3, largest response reached (reported as maximal response), in percent of the reference or control that the assay uses: 44%
Compound 3: middle estimate off by 35 percentage points, on the low side; measured number outside the range, above it.
By their numbers in this assay, from the lowest: compounds 2 and 1 (each within the scatter of the next); then compound 3.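

Among these compounds, the first step between two compounds that differ in one place shows that this read-out responds to the group on this carbonyl carbon: in this assay, ethoxy in place of methylamino goes with a number 35 percentage points higher from compound 1 to compound 3 (beyond the scatter). The end of the side chain is therefore not a silent position, since changing 2-(methylcarbamoyl)ethyl to 2-(ethoxycarbonyl)ethyl while the rest of compound 1 stays the same is enough to move the maximal response beyond the scatter. Nothing available on these compounds accounts for the rise, so it stands as an observation only.

Still open, going by these compounds, is which part of the exchange carries the step: the oxygen in place of the nitrogen with its hydrogen, or the added carbon. A methoxy group, a carboxylic acid or an ethylamino group on the same carbonyl carbon would begin to separate these, and a butoxy group would test a longer chain.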